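Cyclopropyl on the Amide Nitrogen: Compound 4 Foreseen

The compounds below may be only part of what the source reports. "The series", "measured", "known", "first", "only" and "open" are said of these compounds alone.

The measured compounds and their values:
Compound 1, `Cc1ccc(OCC(=O)N(Cc2cccs2)c2ccccc2)cc1`: 23 nM
Compound 2, `Cc1ccc(OCC(=O)N(CCO)Cc2cccs2)cc1`: 900 nM
Compound 3, `COCCN(Cc1cccs1)C(=O)COc1ccc(C)cc1`: 400 nM

In an assay on HEK293 cells for agonist activity at transient receptor potential cation channel subfamily M member 8 (Homo sapiens), read by fluorescence and calcium flux, with a stated time of 15 min (on this read-out higher numbers stand for an effect only at larger amounts of compound and lower numbers for an effect already at smaller amounts), compound 3 gives 400 nM, which places it second highest of the three numbers. Its nearest neighbour is compound 2, with a 2.3-fold lower number from compound 2 to compound 3 (0.35 log units; beyond the scatter), and its furthest is compound 1, with a 17-fold higher number from compound 1 to compound 3 (1.24 log units; beyond the scatter). Compound 4, `Cc1ccc(OCC(=O)N(Cc2cccs2)C2CC2)cc1`, differs from compound 3 as follows: cyclopropyl in place of 2-methoxyethyl on an amide-type nitrogen.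

Within the data shown here, two measured steps bear on this change. The step from compound 1 to compound 3, a 17-fold higher number from compound 1 to compound 3 (1.24 log units; beyond the scatter), shows that exchanging the phenyl for a 2-methoxyethyl on the amide-type nitrogen carried a large penalty, while a 2.3-fold lower number from compound 2 to compound 3 (0.35 log units; beyond the scatter) shows a modest gain on losing the hydrogen-bond donor. Cyclopropyl, a small carbon-only ring with neither donor nor acceptor, is untested here; it sits, in the terms of the measured compounds, between the phenyl of compound 1 and the 2-methoxyethyl of compound 3. A modest drop in number is therefore expected, a 2.0-fold lower number from compound 3 to compound 4 (0.30 log units; within the scatter), with wide uncertainty. Compound 4 is estimated at 200 nM, with a range from 50 nM to 800 nM.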

Compound 4, half-maximal effective concentration: 8 nM
Beside the measured number, compound 4's estimate is 25-fold (1.40 log units) above it; measured number outside the range, below it.
By their numbers in this assay, from the lowest: compound 4; then compound 1; then compound 3; then compound 2.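

In this assay the exchange of 2-methoxyethyl for cyclopropyl on the amide-type nitrogen is large (a 50-fold lower number from compound 3 to compound 4 (1.70 log units; beyond the scatter)), and the exchange of 2-hydroxyethyl for cyclopropyl is larger still (a 110-fold lower number from compound 2 to compound 4 (2.05 log units; beyond the scatter)). Phenyl is therefore not needed at this position: cyclopropyl gives a lower number than phenyl (a 2.9-fold lower number from compound 1 to compound 4 (0.46 log units; beyond the scatter)), and among the four compounds the two rings on this nitrogen stand well below the two oxygen-bearing chains, with no compound going against that split. Nothing measured here explains these differences.

On these data alone, whether the low numbers follow the ring or the absence of oxygen stays open, and a plain propyl chain or a cyclobutyl ring on this nitrogen would bear on that question. The compounds shown also leave open how an amine-bearing chain would behave at this position.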